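The source may report more compounds than this note shows. Statements on the series, on what has been measured and on what is new or still open speak of the compounds shown alone.

Compound 1 `COc1cc(-c2nn(-c3cccc(NC(=O)Nc4cc(C(F)(F)F)cc(C(F)(F)F)c4)c3)cc2-c2ccncc2)ccc1Cl` and compound 2 `O=C(Nc1cccc(-n2cc(-c3ccncc3)c(-c3ccc(Cl)c(O)c3)n2)c1)Nc1cc(C(F)(F)F)cc(C(F)(F)F)c1` share one core; in a functional assay on SK-MEL-28 cells (Homo sapiens) for inhibition, read by sulforhodamine B assay, with a stated time of 48 h (a higher number here means that more compound is tolerated, a lower number that less compound is tolerated), compound 1 gives 3380 nM and compound 2 gives 3090 nM. The change between them, (hydrogen in place of methyl on an oxygen on an aromatic ring), made a step of a 1.1-fold lower number from compound 1 to compound 2 (0.04 log units; within the scatter). Compound 3 `COc1cc(-c2nn(-c3cccc(NC(=O)Nc4ccc(Cl)c(C(F)(F)F)c4)c3)cc2-c2ccncc2)ccc1Cl` has a different core; how it differs from the core of compound 1 is not broken down here. In this assay compound 3 gives 19100 nM. Compound 4 `O=C(Nc1cccc(-n2cc(-c3ccncc3)c(-c3ccc(Cl)c(O)c3)n2)c1)Nc1ccc(Cl)c(C(F)(F)F)c1` stands to compound 3 as compound 2 stands to compound 1, through the same change, (hydrogen in place of methyl on an oxygen on an aromatic ring), at the same place. Because the step of a 1.1-fold lower number from compound 1 to compound 2 (0.04 log units; within the scatter) stayed within the scatter, the step from compound 3 to compound 4 is expected to be a 1.1-fold lower number from compound 3 to compound 4 (0.04 log units; within the scatter). Compound 4 is therefore estimated at 17500 nM, between 8000 nM and 38000 nM.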

Compound 4, concentration lethal to 50% of the cells: 12400 nM
Estimate against measurement, compound 4: 1.4-fold (0.15 log units) above, and the stated range covers the measured number.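

Replacing methoxy with hydroxy on the second core gives a 1.5-fold lower number from compound 3 to compound 4 (0.19 log units; within the scatter) in this assay, so here too the change leaves the number within the usual scatter. Set side by side, the two steps agree: the same change on two cores in this assay, a 1.1-fold lower number (0.04 log units; within the scatter) from compound 1 to compound 2 and a 1.5-fold lower number (0.19 log units; within the scatter) from compound 3 to compound 4, 1.4-fold (0.15 log units) apart, within the scatter of two such steps

Within these two pairs, the change therefore carries over from one core to the other, but two pairs in one cell assay do not show that it would do so on further cores or in other assays.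

The compounds shown leave open what a different group would do at this place. An amine in place of the hydroxy, or a longer chain such as ethyl on the oxygen, could behave differently.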